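Phenyl in place of 2,4-dimethoxyphenyl in compound 1

The compounds below may be only part of what the source reports. "The series", "measured", "known", "first", "only" and "open" are said of these compounds alone.

In a functional assay on HCC827 cells (Homo sapiens) for inhibition, read by fluorescence, with a stated time of 72 h (a lower number here means a stronger inhibitor of growth, a higher number a weaker inhibitor of growth), compound 1 `COc1ccc(Nc2nc(N[C@H]3CC[C@H](N)CC3)nc3c2ncn3CCC(C)C)c(OC)c1` gives 32900 nM. That is the highest of the three numbers measured, although compound 2 `N[C@H]1CC[C@H](Nc2nc(Nc3ccc(O)cc3)c3ncn(C4CCCCC4)c3n2)CC1`, at 32500 nM, stands level with it within the scatter. Compound 3 `CCCCn1cnc2c(Nc3ccc(Cl)cc3)nc(N[C@H]3CC[C@H](N)CC3)nc21` gives 10800 nM, a lower number than compound 1 by a gap beyond the scatter.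

Compound 4 `CC(C)CCn1cnc2c(Nc3ccccc3)nc(N[C@H]3CC[C@H](N)CC3)nc21` keeps the rest of compound 1 and changes one place: phenyl in place of 2,4-dimethoxyphenyl on a nitrogen on an aromatic ring. It carries phenyl in place of 2,4-dimethoxyphenyl on a nitrogen on an aromatic ring.

For the measured compounds named here, no two measured compounds differ in only one place, so the size of this change in this assay has not been measured directly. Neither compound 2 nor compound 3 carries the 2,4-dimethoxyphenyl group, yet compound 2 at 32500 nM shows no gain over compound 1, whereas compound 3 at 10800 nM does. These two compounds give only a weak hint of direction, and they also differ from compound 1 elsewhere.

The expected change is small and toward a lower number, and it may well stay within the scatter: a 1.6-fold lower number from compound 1 to compound 4 (0.22 log units; within the scatter). For compound 4 the estimated value is 20000 nM, with an expected range from 7000 nM to 50000 nM.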

Compound 4, concentration for 50% growth inhibition: 21700 nM
Estimate against measurement, compound 4: 1.1-fold (0.04 log units) below; the range from low to high includes it.
By their numbers in this assay, from the lowest: compounds 3, 4, 2 and 1 (each within the scatter of the next, the first and the last beyond it).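

In this assay, the replacement of 2,4-dimethoxyphenyl by phenyl on a nitrogen on an aromatic ring can now be read as a single change with the rest of compound 1 held fixed: a 1.5-fold lower number from compound 1 to compound 4 (0.18 log units; within the scatter). The earlier compounds shown here differed from compound 1 in other places as well, so they could not isolate this change. It shows that, on this scaffold, removing the methoxy groups together leaves the growth-inhibition number level with that of compound 1 within the scatter, and no measurement shown here offers an explanation for this.

From the compounds shown here alone, what stays open is whether each methoxy group has the same lack of effect on its own, as the step removes them together and a phenyl carrying a single methoxy would be needed to separate them. Also open, going by these compounds, is whether this position responds at all to a different kind of group, such as a nitrile or a carboxylic acid on the phenyl ring, and whether the step holds when the rest of compound 1 is changed.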